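The source may report more compounds than this note shows. Statements on the series, on what has been measured and on what is new or still open speak of the compounds shown alone.

Measured so far in an ADME assay on HEp-2 cells (Homo sapiens) for cytotoxicity, read by CCK-8 assay, with a stated time of 5 days; on this read-out lower numbers stand for higher toxicity in this test and higher numbers for lower toxicity in this test:

Compound 1 `Cc1ccc2nc(N3CCCc4ccc(F)cc4C3)cc(NCC3(N)COC3)c2c1` gives > 100000 nM, which is a limit of this assay rather than a number.
Compound 2 `NCCNc1cc(N2CCCc3ccccc3C2)nc2cccc(Cl)c12` gives 23000 nM.
Compound 3 `CNCCNc1cc(N2CCCc3ccc(F)cc3C2)nc2ccc(C)cc12` gives 29000 nM.

Among the two numbers, compound 3 has the highest; its nearest neighbour is compound 2, whose value sits within the scatter of it, so the two cannot be told apart. Among the measured compounds shown here, the only step measured so far, an at least 3.4-fold lower number from compound 1 to compound 3 (0.53 log units; beyond the scatter), concerns a different change, at a saturated chain carbon, and only one of its two ends is a number, the other being the limit (the limit of > 100000 nM in this assay, at which 1 of the 3 values shown sits).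

Compound 4 `Cc1ccc2nc(N3CCCc4ccc(F)cc4C3)cc(NC(C)CN)c2c1` is built from the same atoms as compound 3, joined differently: 1-(aminomethyl)ethyl in place of 2-(methylamino)ethyl on a nitrogen on an aromatic ring. For the measured compounds named here, no measured step bears directly on such a rearrangement of the side chain. Going by the values given here, with compound 3 at 29000 nM and no step of this kind to draw on, the expectation is a step of a 1.0-fold higher number from compound 3 to compound 4 (0.01 log units; within the scatter), that is, none beyond the scatter. Compound 4 is therefore estimated at 30000 nM, within a range of 12000 nM to 75000 nM.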

Compound 4, half-maximal cytotoxic concentration: 25000 nM
For compound 4 the middle estimate is 1.2-fold (0.08 log units) above the measured one; low and high end bracket the measured number.
By their numbers in this assay, from the lowest: compounds 2, 4 and 3 (each within the scatter of the next). At a limit, above all of these: compound 1.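

In this assay, rearranging the same atoms within the side chain on a nitrogen on an aromatic ring makes no difference that can be told from the scatter: a 1.2-fold lower number from compound 3 to compound 4 (0.06 log units; within the scatter). Among the compounds shown here, this is new, as no earlier step compared two chains built from the same atoms, and here 2-(methylamino)ethyl and 1-(aminomethyl)ethyl cannot be told apart. The (3-aminooxetan-3-yl)methyl chain of compound 1 stands apart, with an at least 4.0-fold lower number from compound 1 to compound 4 (0.60 log units; beyond the scatter), but the compound 1 end of that step is a limit, so the step has no exact size: the limit of > 100000 nM in this assay, at which 1 of the 4 values shown sits.

From the compounds shown here alone, it remains open whether a dimethylamine or a carboxylic acid at the end of the chain, or a longer chain, would read like compound 3 and compound 4 or like compound 1. Going by these compounds, whether the oxetane ring alone sets compound 1 apart also stays open.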